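The compounds below may be only part of what the source reports. "The series", "measured", "known", "first", "only" and "open" are said of these compounds alone.

Compound 1, with the structure `CCOC(=O)c1cnc(N2CCN(Cc3ccc(C#N)cc3)CC2)nc1Oc1c(C)cc(-c2ccc(C#N)cc2)cc1C`, serves as the starting point. In an ADME assay on MT4 cells (Homo sapiens) for cytotoxicity, read by MTT assay, with a stated time of 4 days (a lower number here means that less compound is tolerated, a higher number that more compound is tolerated), compound 1 gives > 125000 nM, which is a limit of the assay rather than a measured number. Compound 2, with the structure `CCOC(=O)c1cnc(N2CCN(Cc3ccc(C(F)(F)F)cc3)CC2)nc1Oc1c(C)cc(-c2ccc(C#N)cc2)cc1C`, gives > 125000 nM in this assay, again only a limit. Compound 3, with the structure `CCOC(=O)c1cnc(N2CCN(Cc3cccc(C(=O)OC)c3)CC2)nc1Oc1c(C)cc(-c2ccc(C#N)cc2)cc1C`, gives > 125000 nM, once more a limit. Because all three values sit at the limit of > 125000 nM in this assay, at which 3 of the 3 values shown sit, none of the steps among them can be read: the step that the two limits leave unreadable from compound 1 to compound 2, the step that the two limits leave unreadable from compound 1 to compound 3 and the step that the two limits leave unreadable from compound 2 to compound 3 each stay hidden behind the limit.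

The compound not yet measured is compound 4, with the structure `CCOC(=O)c1cnc(N2CCN(Cc3ccc(S(C)(=O)=O)cc3)CC2)nc1Oc1c(C)cc(-c2ccc(C#N)cc2)cc1C`. It differs from compound 1 as follows: methylsulfonyl in place of cyano on an aromatic carbon. The three measured steps all concern changes on the same benzyl arm attached to the ring nitrogen, and each of them left the read-out at the limit. Among the compounds with values here, no measured step therefore shows any movement in this assay, and the expectation for compound 4 is that it too will tolerate the highest tested amount, with an expected step of a number no higher from compound 1 to compound 4 (the limit leaves the size open). Compound 4 is accordingly estimated to give 125000 nM in this assay, expected to fall between 60000 nM and 200000 nM, most likely reported again as a limit.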

Compound 4, half-maximal cytotoxic concentration: > 125000 nM
Compound 4 was reported as a limit; the forecaster's own chance of this, stated with the estimate: 85%; the middle value sits exactly at the limit.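

In this assay compound 4 gives > 125000 nM, which is a limit of the assay. No step linking compound 4 to compound 1, compound 2 or compound 3 can be read, because all four compounds share the same limit: the limit of > 125000 nM in this assay, at which 4 of the 4 values shown sit.

The compounds shown leave open where the true half-maximal cytotoxic concentration of each lies, and whether these benzyl changes alter it at all.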